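Adding a Second Fluoro Group to Compound 3

The source may report more compounds than this note shows. Statements on the series, on what has been measured and on what is new or still open speak of the compounds shown alone.

Compound 1 `COc1ccc(C(=O)c2cc(OC)c(OC)c(OC)c2)cc1N`: 80 nM
Compound 2 `COc1ccc(C(=O)c2cc(OC)c(OC)c(OC)c2)cc1NC(=O)/C=C/c1cc(OC)c(OC)c(OC)c1`: 2100 nM
Compound 3 `COc1ccc(C(=O)c2cc(OC)c(OC)c(OC)c2)cc1NC(=O)/C=C/c1ccc(F)cc1`: 300 nM

In a functional assay on ME-180 cells (Homo sapiens) for cytotoxicity, read by MTT assay, with a stated time of 72 h (a higher number here means a weaker inhibitor, a lower number a stronger inhibitor), compound 3 gives 300 nM, the second highest of the three numbers. Its nearest neighbour is compound 1, with a 3.8-fold higher number from compound 1 to compound 3 (0.57 log units; beyond the scatter); furthest away lies compound 2, with a 7.0-fold lower number from compound 2 to compound 3 (0.85 log units; beyond the scatter). Compound 4 `COc1ccc(C(=O)c2cc(OC)c(OC)c(OC)c2)cc1NC(=O)/C=C/c1ccc(F)c(F)c1` differs from compound 3 by fluoro in place of hydrogen on an aromatic carbon. Neither measured step bears directly on this change: one replaces the hydrogen on the nitrogen by the whole (2-(4-fluorophenyl)ethenyl)carbonyl group, the other exchanges 3,4,5-trimethoxyphenyl for 4-fluorophenyl. Among the measured compounds shown here, with no step of the same kind to go by, a change within the scatter is expected, no change at the digits printed from compound 3 to compound 4 (within the scatter). Compound 4 is therefore estimated at 300 nM in this assay, within 120 nM to 900 nM.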

Compound 4, half-maximal inhibitory concentration: 8900 nM
Beside the measured number, compound 4's estimate is 30-fold (1.47 log units) below it, outside the stated range (above it).
By their numbers in this assay, from the lowest: compound 1; then compound 3; then compound 2; then compound 4.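

Adding one fluoro group, which turns 4-fluorophenyl into 3,4-difluorophenyl, gives a 30-fold higher number from compound 3 to compound 4 (1.47 log units; beyond the scatter), a larger step than either earlier exchange of a whole group. The fluoro-bearing ring no longer keeps its advantage over 3,4,5-trimethoxyphenyl in this assay, since the comparison now reads a 4.2-fold higher number from compound 2 to compound 4 (0.63 log units; beyond the scatter). Nothing available here explains why this single atom matters so much.

As far as these compounds go, it remains open whether a chloro or methoxy group on the same aromatic carbon would behave alike. From the compounds shown here alone, it also remains open whether this fluoro group would have the same effect without the fluoro group ortho to it.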